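A few compounds are considered here, and "the series" means these few. Any claim that something is new, unique, unknown or untested is made for them only; others in the source may bear on it.

Measured compounds:
- compound 1 `COc1ccc(OC)c(-c2cc(-c3ccccc3)nn2-c2ccc(S(=O)(=O)NC(C)=O)cc2)c1`: 18200 nM
- compound 2 `Oc1ccc(O)c(-c2cc(-c3ccccc3)nn2-c2ccccc2)c1`: 77400 nM
- compound 3 `Oc1ccc(O)c(-c2cc(-c3ccc(Cl)cc3)nn2-c2ccccc2)c1`: 16800 nM

All three were tested in a functional assay on cells (Cancer cell lines, Homo sapiens) for cytotoxicity, read by sulforhodamine B assay, with a stated time of 48 h; on this read-out lower numbers stand for stronger inhibition of growth and higher numbers for weaker inhibition of growth. Compound 2 gives the highest of the three numbers; compound 1 lies nearest to it, and compound 3 furthest, both beyond the scatter, so compound 2 is the weakest of the measured set.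

The step from compound 2 to compound 4 `CC(=O)NS(=O)(=O)c1ccc(-n2nc(-c3ccccc3)cc2-c2cc(O)ccc2O)cc1` brings in acetylsulfamoyl in place of hydrogen on an aromatic carbon. For the measured compounds named here, the single measured step, a 4.6-fold lower number from compound 2 to compound 3 (0.66 log units; beyond the scatter), concerns a chloro group on a different ring and does not bear on this change. Going by the values given here, compound 1 carries the same acetylsulfamoyl group, but it also differs from compound 2 in the two methoxy groups in place of the two hydroxy groups, so no single step between them is available; their two values show only that compound 1 sits well below compound 2 in this assay. On that basis a lowering of the number from compound 2 to compound 4 is expected, of the order of a 3.1-fold lower number from compound 2 to compound 4 (0.49 log units; beyond the scatter), though with little support. Compound 4 is therefore estimated at 25000 nM, within a range of 8000 nM to 80000 nM.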

Compound 4, concentration for total growth inhibition: 100000 nM
Estimate against measurement, compound 4: 4.0-fold (0.60 log units) below, outside the stated range (above it).
By their numbers in this assay, from the lowest: compounds 3 and 1 (each within the scatter of the next); then compounds 2 and 4 (each within the scatter of the next).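

In this assay, acetylsulfamoyl on the aromatic carbon para to a large group gives a 1.3-fold higher number from compound 2 to compound 4 (0.11 log units; within the scatter), so with the two hydroxy groups present, this position takes a group of this size with no change in the read-out beyond the scatter. With acetylsulfamoyl held constant, 2,5-dihydroxyphenyl in place of 2,5-dimethoxyphenyl gives a 5.5-fold higher number from compound 1 to compound 4 (0.74 log units; beyond the scatter), which ties the lower number of compound 1 to its 2,5-dimethoxyphenyl group and not to acetylsulfamoyl alone. Nothing shown accounts for either step.

The compounds shown leave open what acetylsulfamoyl does at this position when 2,5-dimethoxyphenyl is present, as they include no partner of compound 1 with hydrogen in its place. They also leave open whether another group on this aromatic carbon, such as an amine or a carboxylic acid, would shift the number beyond the scatter, and whether the chloro step seen on the other ring would carry over to compounds bearing acetylsulfamoyl.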